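Anilino for hydroxy on the carbonyl carbon of compound 3

The source may hold more compounds than are shown below. What is called first, only, known or untested is meant among the compounds shown, and "the series" means these compounds.

Compound 1 `Cc1ccc(CSc2nc(C3CCCCC3)c(C#N)c(=O)[nH]2)c(C)c1` gives 15700 nM in an assay on isolated protein for inhibition of Rap guanine nucleotide exchange factor 4 (Homo sapiens), read by fluorescence and cAMP accumulation; a lower number here means a stronger inhibitor, a higher number a weaker inhibitor. Compound 2 `N#Cc1c(C2CCCCC2)nc(SCc2ccccc2)[nH]c1=O` gives 30500 nM in this assay; the pair shows a 1.9-fold higher number from compound 1 to compound 2 (0.29 log units; within the scatter). Compound 3 `N#Cc1c(C2CCCCC2)nc(SCC(=O)O)[nH]c1=O` reaches only a limit of the measurement, > 300000 nM, in this assay. Compound 3 thus stands at the weak end of the three, a position recorded as the limit of > 300000 nM in this assay, at which 1 of the 3 values shown sits. The steps into it were large: an at least 19-fold higher number from compound 1 to compound 3 (1.28 log units; beyond the scatter) and an at least 9.8-fold higher number from compound 2 to compound 3 (0.99 log units; beyond the scatter). Compound 4 `N#Cc1c(C2CCCCC2)nc(SCC(=O)Nc2ccccc2)[nH]c1=O` differs from compound 3 by anilino in place of hydroxy on a carbonyl carbon. Both measured steps bear on this change in reverse: introducing the carboxy raised the number sharply, so placing an aromatic ring back onto that chain is expected to lower the number in this assay, by an at least 5.0-fold lower number from compound 3 to compound 4 (0.69 log units; beyond the scatter). Compound 4 is therefore estimated at 60000 nM, with an expected range of 15000 nM to 300000 nM.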

Compound 4, half-maximal inhibitory concentration: > 300000 nM
Compound 4: a limit, no number; the forecaster's own chance of this, stated with the estimate: 30%; middle value at least 5.0-fold (0.69 log units) from the limit.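

No step can be read between compound 3 and compound 4 in this assay, since both values are limits: the limit of > 300000 nM in this assay, at which 2 of the 4 values shown sit.

From the compounds shown here alone, whether anilino in place of hydroxy on a carbonyl carbon changes the number at all remains open.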